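Azetidine in place of diethylamino on the shared core

The compounds below may be only part of what the source reports. "The series", "measured", "known", "first", "only" and "open" are said of these compounds alone.

Compound 1 `CC(C)(C)Nc1ncnc2c1ncn2Cc1ccccc1F`, compound 2 `CCN(C)c1ncnc2c1ncn2Cc1ccccc1F` and compound 3 `CCN(CC)c1ncnc2c1ncn2Cc1ccccc1F` share one core and differ only in the amino group on the aromatic carbon. In a functional assay on the whole organism with Rattus norvegicus as the target, in the maximal electroshock model (a higher number here means that more compound is needed for the effect, a lower number that less compound is needed), compound 1 reaches only a limit of the assay, > 50 mg/kg. Compound 2 gives 2.9 mg/kg in this assay, and compound 3 gives 4.2 mg/kg. Among the two numbers, compound 3 sits alongside compound 2, the step between them being a 1.4-fold higher number from compound 2 to compound 3 (0.16 log units; within the scatter). The two steps from the limit are large: an at least 17-fold lower number from compound 1 to compound 2 (1.23 log units; beyond the scatter) and an at least 11-fold lower number from compound 1 to compound 3 (1.07 log units; beyond the scatter).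

Compound 4 `Fc1ccccc1Cn1cnc2c(N3CCC3)ncnc21` differs from compound 3 in one place: azetidin-1-yl in place of diethylamino on an aromatic carbon. The measured steps that bear on this change all concern the same position. Both large steps replace a secondary amine carrying tert-butyl with a dialkylamino group; compound 4 keeps a tertiary nitrogen, as compound 2 and compound 3 do, and the step between those two stays within the scatter. For compound 4 no step beyond the scatter is therefore expected in this assay. Compound 4 is estimated at 3.5 mg/kg, with a range from 1.5 mg/kg to 9 mg/kg. This estimate corresponds to an expected step of a 1.2-fold lower number from compound 3 to compound 4 (0.08 log units; within the scatter) for compound 4.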

Compound 4, dose for half-maximal effect: > 50 mg/kg
Compound 4: no number, only a limit; the forecaster's own chance of this, stated with the estimate: 10%; middle value at least 14-fold (1.15 log units) from the limit.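

Working notes on the amino position: in this assay, a tertiary nitrogen on this aromatic carbon does not by itself keep the low numbers of the open-chain groups. Tying the two chains into azetidin-1-yl gives an at least 11-fold higher number from compound 3 to compound 4 (1.07 log units; beyond the scatter), and the comparison with the ethyl(methyl)amino group gives an at least 17-fold higher number from compound 2 to compound 4 (1.23 log units; beyond the scatter), so this position separates open-chain dialkylamino groups from a four-membered ring, a difference that the small step between compound 2 and compound 3 gave no sign of. Compound 4 stands at a limit of the assay, > 50 mg/kg, and compound 1 shares that limit, so the step between these two cannot be read: the limit of > 50 mg/kg in this assay, at which 2 of the 4 values shown sit.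

The compounds shown do not tell whether the change follows from closing a ring in general or from the four-membered ring in particular; pyrrolidin-1-yl and piperidin-1-yl on the same aromatic carbon would separate these two readings. Also open, from the compounds shown here alone, is how much of the large step from compound 1 comes from the tert-butyl group and how much from the secondary amine, which a smaller group such as methylamino would help to settle.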